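Swapping the Amide Cap on the Shared Core

The compounds below may be only part of what the source reports. "The series", "measured", "known", "first", "only" and "open" are said of these compounds alone.

Of the compounds shown here, three have been measured in an assay on cells for positive allosteric modulation of Cystic fibrosis transmembrane conductance regulator variant F508del (Homo sapiens), with stated times of 10 min and 7 s, in the presence of a further agent that is not named here; a higher number here means that more compound is needed for the effect, a lower number that less compound is needed. Compound 1 `Cc1ccc(C(=O)Nc2sc3c(c2C(N)=O)CCCC3)s1` gives 652 nM, and compound 2 `Cc1ccc(C(=O)Nc2sc3c(c2C(N)=O)CCOC3)s1` gives 778 nM. Compound 3 `CC1(C)Cc2c(sc(NC(=O)C3(O)CC3)c2C(N)=O)C(C)(C)O1` gives 23 nM, the lowest of the three numbers, and its distance to each of the other two lies beyond the usual scatter, so compound 3 needs clearly less material for the effect than compound 1 or compound 2.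

Compound 4 `Cc1cn[nH]c1C(=O)Nc1sc2c(c1C(N)=O)CC(C)(C)OC2(C)C` keeps the core of compound 3 and alters only the group on the amide carbonyl: 4-methyl-1H-pyrazol-5-yl in place of 1-hydroxycyclopropyl on a carbonyl carbon. Within the data shown here, no measured pair in this set shows this particular exchange, so the size of the step can only be guessed. Compounds 1 and 2 carry an aromatic ring on that carbonyl and sit at far higher numbers than compound 3, but they also have different cores, so they do not settle the question.

The expectation is a modest rise in the number, that is, a step of a 2.6-fold higher number from compound 3 to compound 4 (0.42 log units; beyond the scatter) that may or may not clear the scatter. For compound 4 the estimated value in this assay is 60 nM, with a plausible range from 15 nM to 250 nM.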

Compound 4, half-maximal effective concentration: 2 nM
Beside the measured number, compound 4's estimate is 30-fold (1.48 log units) above it, outside the stated range (below it).
By their numbers in this assay, from the lowest: compound 4; then compound 3; then compounds 1 and 2 (each within the scatter of the next).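

Holding the core of compound 3 fixed, this single exchange on a carbonyl carbon, 4-methyl-1H-pyrazol-5-yl in place of 1-hydroxycyclopropyl, gives a 12-fold lower number from compound 3 to compound 4 (1.06 log units; beyond the scatter) in this assay and so shows that the group at this position strongly affects how much compound is needed. The earlier compounds shown here could not show this: compounds 1 and 2 differ from compound 3 in more than one place, so their higher numbers could not be assigned to the group on the carbonyl, and on this core an aromatic ring in that position clearly goes with a lower number than 1-hydroxycyclopropyl. The data offer no measured explanation for the size of this step.

This single pair cannot tell which part of the new group matters, and a pyrazole without the methyl or a plain phenyl ring on the same carbonyl would help separate the contribution of the methyl from that of the ring nitrogens. On these data alone, it also remains open whether 4-methyl-1H-pyrazol-5-yl would bring a similar step on the core of compound 1 or compound 2.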